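Replacing 1H-1,2,4-triazol-1-yl with 1H-pyrrol-1-yl on compound 1

This account rests on a few compounds, and the source may have more. Where it says the series, first, only, none or still open, it means among the compounds named here.

In a functional assay on K562 cells (Homo sapiens) for antiproliferative activity, read by MTT assay, with a stated time of 48 h (a higher number here means a weaker inhibitor, a lower number a stronger inhibitor), compound 1 (`Cn1cc(C2=C(c3nn(CCCn4cncn4)c4ncccc34)C(=O)N(c3ccccc3)C2=O)c2ccccc21`) reads > 100000 nM, which is a limit and not a number. It sits at the limit of > 100000 nM in this assay, at which 2 of the 3 values shown sit.

Compound 4 (`Cn1cc(C2=C(c3nn(CCCn4cccc4)c4ncccc34)C(=O)N(c3ccccc3)C2=O)c2ccccc21`) carries 1H-pyrrol-1-yl in place of 1H-1,2,4-triazol-1-yl on a saturated chain carbon, three bonds along the chain from an aromatic nitrogen.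

For the measured compounds named here, no measured step makes this exact change. The nearest evidence concerns a whole chain. In this assay, compound 2 (`Cn1cc(C2=C(c3nn(CCCn4ccnc4)c4ncccc34)C(=O)NC2=O)c2ccccc21`) gives 13800 nM. Compound 3 (`Cn1cc(C2=C(c3n[nH]c4ncccc34)C(=O)NC2=O)c2ccccc21`) reads > 100000 nM, again a limit. Hydrogen in place of 3-(1H-imidazol-1-yl)propyl on an aromatic nitrogen gives an at least 7.2-fold higher number from compound 2 to compound 3 (0.86 log units; beyond the scatter). Compound 1 also carries a chain and still yields no number, so this step offers only weak guidance on the present swap.

At most a modest move toward a lower number is therefore expected, with an at least 1.2-fold lower number from compound 1 to compound 4 (0.09 log units; that floor lies within the scatter) as the estimated step. Compound 4 is expected at about 80000 nM, within an estimated range of 20000 nM to 100000 nM.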

Compound 4, half-maximal inhibitory concentration: 36600 nM
Estimate against measurement, compound 4: 2.2-fold (0.34 log units) above, within the range that was stated.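

In this assay, exchanging only the ring at the end of the chain, with 1H-pyrrol-1-yl in place of 1H-1,2,4-triazol-1-yl, gives an at least 2.7-fold lower number from compound 1 to compound 4 (0.43 log units; beyond the scatter). The earlier change gave an at least 7.2-fold higher number from compound 2 to compound 3 (0.86 log units; beyond the scatter), but it removed the whole 3-(1H-imidazol-1-yl)propyl chain, so it could not show that the ring alone alters the reading while the chain stays in place. The new step is only a floor, as compound 1 reads > 100000 nM, which is a limit: the limit of > 100000 nM in this assay, at which 2 of the 4 values shown sit.

The compounds shown leave open how a piperidin-1-yl amine, a carboxylic acid or a phenyl ring at the end of the chain would read, and what a longer chain would do. On these data alone, compound 2 and compound 4 differ in more than one place, so the part played by the phenyl group on the core also stays open.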